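A Carbonyl Substituent Exchange Leading to Compound 4

This account rests on a few compounds, and the source may have more. Where it says the series, first, only, none or still open, it means among the compounds named here.

Values in an ADME assay on CEM-SS cells (Homo sapiens) for cytotoxicity, read by XTT assay, with a stated time of 6 days (a lower number here means that less compound is tolerated, a higher number that more compound is tolerated), stand as follows

Compound 1 `CCCC(=O)OCSc1ccccc1C(=O)NCCCC(N)=O` gives 56.6 uM
Compound 2 `CCCC(=O)OCSc1ccccc1C(=O)NCCCCC(N)=O` gives 51.7 uM
Compound 3 `CCCC(=O)OCSc1ccccc1C(=O)OCC(N)=O` gives 82.1 uM

Compound 3, at 82.1 uM, lies within the scatter of both compound 1 and compound 2. Compound 4 `CCCC(=O)OCSc1ccccc1C(=O)N(C)CC(N)=O` differs from it by (carbamoylmethyl)(methyl)amino in place of carbamoylmethoxy on a carbonyl carbon, with (carbamoylmethyl)(methyl)amino in place of carbamoylmethoxy on a carbonyl carbon. Among the compounds with values here, two measured steps bear on this exchange, though they run towards carbamoylmethoxy: a 1.5-fold higher number from compound 1 to compound 3 (0.16 log units; within the scatter) and a 1.6-fold higher number from compound 2 to compound 3 (0.20 log units; within the scatter). Within the data shown here, both are small, yet no measured compound carries the (carbamoylmethyl)(methyl)amino group itself. No step beyond the scatter is therefore expected in this assay. The estimated step is a 1.3-fold lower number from compound 3 to compound 4 (0.12 log units; within the scatter). For compound 4 the estimate is 62 uM, with an expected range from 35 uM to 110 uM.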

Compound 4, half-maximal toxic concentration: 55.3 uM
Estimate against measurement, compound 4: 1.1-fold (0.05 log units) above; the measured number falls inside the stated range.
By their numbers in this assay, from the lowest: compounds 2, 4, 1 and 3 (each within the scatter of the next).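

In this assay the (carbamoylmethyl)(methyl)amino group on this carbonyl carbon stays within the scatter of all three earlier compounds (a 1.5-fold lower number from compound 3 to compound 4 (0.17 log units; within the scatter); a 1.1-fold higher number from compound 2 to compound 4 (0.03 log units; within the scatter); a 1.0-fold lower number from compound 1 to compound 4 (0.01 log units; within the scatter)). Across the four compounds, this place has now carried carbamoylmethoxy, (3-carbamoylpropyl)amino, (4-carbamoylbutyl)amino and (carbamoylmethyl)(methyl)amino without any step beyond the scatter. No measurement shown here gives a reason for this. On these data alone, whether a carboxylic acid or a longer chain on this carbonyl carbon would stay within the scatter remains open.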